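Removing One Methoxy Group From the Aryl Substituent

This account rests on a few compounds, and the source may have more. Where it says the series, first, only, none or still open, it means among the compounds named here.

Three analogues built on a shared core were tested in an assay on membranes from brain for binding affinity to adenosine receptor A1 (Rattus norvegicus), read by radioligand binding; on this read-out higher numbers stand for weaker inhibition and lower numbers for stronger inhibition. Compound 1 `COc1ccccc1-c1nc(O)c2c(n1)c(C)nn2C` gives 10000 nM. Compound 2 `COc1ccc(-c2nc(O)c3c(n2)c(C)nn3C)c(OC)c1` gives 5430 nM, and compound 3 `COc1cc(OC)cc(-c2nc(O)c3c(n2)c(C)nn3C)c1` gives 7060 nM; the difference between the cores of compound 2 and compound 3 is not broken down here, and their two values lie within the scatter of each other. Between compound 2 and compound 1 the change is hydrogen in place of methoxy on an aromatic carbon, and the measured step is a 1.8-fold higher number from compound 2 to compound 1 (0.27 log units; within the scatter).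

Compound 4 `COc1cccc(-c2nc(O)c3c(n2)c(C)nn3C)c1` has not yet been measured. It arises from compound 3 by hydrogen in place of methoxy on an aromatic carbon, the same kind of change as before, though the place differs: here it is meta to a large group and meta to a methoxy group, whereas in compound 1 it was para to a large group and meta to a methoxy group. Compound 4 is therefore expected to give about 9000 nM in this assay, because the earlier step of a 1.8-fold higher number from compound 2 to compound 1 (0.27 log units; within the scatter) stayed within the scatter. For compound 4 the expected range runs from 4000 nM to 20000 nM. The expected step is a 1.3-fold higher number from compound 3 to compound 4 (0.11 log units; within the scatter).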

Compound 4, half-maximal inhibitory concentration: 1470 nM
Estimate against measurement, compound 4: 6.1-fold (0.79 log units) above; the whole stated range lies above it.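

In this assay, hydrogen in place of methoxy on an aromatic carbon gives a 4.8-fold lower number from compound 3 to compound 4 (0.68 log units; beyond the scatter). The earlier step of the same kind therefore does not carry over to this second pair in either size or direction: the same change on two cores in this assay, a 1.8-fold higher number (0.27 log units; within the scatter) from compound 2 to compound 1 and a 4.8-fold lower number (0.68 log units; beyond the scatter) from compound 3 to compound 4, 8.8-fold (0.95 log units) apart, beyond the scatter of two such steps

This shows that, within this series, the change cannot be moved from one core to another as a fixed step, and that the result on one core did not foretell the result on the other. Among these compounds, with only two pairs, whose changes also lie at different places on the aromatic ring, it does not show why the steps part or give a rule for any further core.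

The compounds shown carry only hydrogen or methoxy at the varied places on the aromatic ring. Going by these compounds, what a chlorine atom, an amine or a longer chain such as butoxy would do at those places remains open, as does whether any such group would follow either of the two steps.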